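Azetidine amide series: cyclopropylcarbonyl to ethyl on the ring nitrogen

A few compounds are considered here, and "the series" means these few. Any claim that something is new, unique, unknown or untested is made for them only; others in the source may bear on it.

Three compounds have numbers in a functional assay on MIA PaCa-2 cells (Homo sapiens) for inhibition, read by MTT assay, with a stated time of 3 days; on this read-out higher numbers stand for weaker inhibition and lower numbers for stronger inhibition. Compound 1 `CC(C)c1noc(N2CCN(C(=O)[C@@H]3CCCN(S(=O)(=O)c4ccc(S(=O)(=O)C(C)C)cc4)C3)CC2)n1` gives 30 nM; compound 3 `CCOC(=O)[C@@H]1CCN(S(=O)(=O)c2ccc(S(=O)(=O)N(CC)CC)cc2)C1` gives 1500 nM. Compound 2 `CCN(CC)S(=O)(=O)c1ccc(S(=O)(=O)N2CCC[C@@H](C(=O)NC3CN(C(=O)C4CC4)C3)C2)cc1` gives 3100 nM, the highest of the three numbers, with compound 3 nearest and compound 1 furthest, both gaps beyond the scatter.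

Compound 4 `CCN1CC(NC(=O)[C@@H]2CCCN(S(=O)(=O)c3ccc(S(=O)(=O)N(CC)CC)cc3)C2)C1` is not yet measured. It differs from compound 2 in one place: ethyl in place of cyclopropylcarbonyl on an amine nitrogen in a ring.

Among the compounds with values here, no measured pair shows this change, so its size is unknown from the series. For compound 4 the step is expected to be small, a 1.1-fold higher number from compound 2 to compound 4 (0.05 log units; within the scatter), not clearly beyond the scatter in either direction. Compound 4 is therefore estimated at 3500 nM, with a range from 1000 nM to 12000 nM in this assay .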

Compound 4, half-maximal inhibitory concentration: > 10000 nM
Compound 4 was reported as a limit (the forecaster's own chance of this, stated with the estimate: 10%); at least 2.8-fold (0.45 log units) between middle value and limit.
By their numbers in this assay, from the lowest: compound 1; then compound 3; then compound 2. At a limit, above all of these: compound 4.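

In this assay, within the data shown here, ethyl in place of cyclopropylcarbonyl on this amine nitrogen gives an at least 3.2-fold higher number from compound 2 to compound 4 (0.50 log units; beyond the scatter), the first reading of this change. Compound 4 is reported only as a limit, > 10000 nM. The position is thus not indifferent to its group: the cyclopropylcarbonyl compound keeps a measurable value, and the ethyl compound does not.

The full size of the step stays open: the limit of > 10000 nM in this assay, at which 1 of the 4 values shown sits. Neither acetyl nor cyclopropylmethyl on this nitrogen stands among the compounds shown, so the roles of the carbonyl and the three-membered ring cannot be separated.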